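Swapping the dimethylphenyl pattern on an inactive amide

This account rests on a few compounds, and the source may have more. Where it says the series, first, only, none or still open, it means among the compounds named here.

Measured compounds:
Compound 1 `COc1ccc(-c2cc(-c3ccccc3)c(C#N)c(SCC(=O)Nc3cc(C)cc(C)c3)n2)cc1`: 5780 nM
Compound 2 `Cc1ccc(-c2cc(-c3ccc(F)cc3)nc(SCC(=O)Nc3cccc(C)c3)c2C#N)cc1`: 6720 nM
Compound 3 `COc1ccc(-c2cc(-c3ccc(OC)cc3)c(C#N)c(SCC(=O)Nc3ccc(C)c(C)c3)n2)cc1`: "not active" (no number reported)

In a functional assay on MG-63 cells (Homo sapiens) for inhibition, read by MTT assay, with a stated time of 72 h (on this read-out lower numbers stand for an effect already at smaller amounts and higher numbers for an effect only at larger amounts of compound), compound 1 gives 5780 nM and compound 2 gives 6720 nM, two values within the usual scatter of each other. Compound 3 stands apart: in this assay compound 3 is reported as "not active" (no number reported), with no number attached, so it shows no measurable effect in the range tested. Compound 4 `COc1ccc(-c2cc(-c3ccc(OC)cc3)c(C#N)c(SCC(=O)Nc3c(C)cccc3C)n2)cc1` differs from compound 3 only in 2,6-dimethylphenyl in place of 3,4-dimethylphenyl on an amide-type nitrogen. Among the compounds with values here, no measured pair isolates this change, so its size and direction are unknown. Given that compound 3 gives "not active" (no number reported), compound 4 is expected to remain weak, and its estimate in this assay is 15000 nM, ranging from 4000 nM to 60000 nM.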

Compound 4, half-maximal effective concentration: 35400 nM
Beside the measured number, compound 4's estimate is 2.4-fold (0.37 log units) below it, and the stated range covers the measured number.
By their numbers in this assay, from the lowest: compounds 1 and 2 (each within the scatter of the next); then compound 4.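

Within the data shown here, compound 3 has no number, and compounds 1 and 2 differ from compound 4 in more than one place, so no step to compound 4 can be read. Nothing shown here offers an explanation for the result. In this assay the compounds shown leave open how large the change from 3,4-dimethylphenyl to 2,6-dimethylphenyl is.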